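This account rests on a few compounds, and the source may have more. Where it says the series, first, only, none or still open, it means among the compounds named here.

For the measured compounds named here, compound 2 `CCCC(C)Oc1cccc2ccc(N)nc12` gives 860 nM in a functional assay on IMR-32 cells with melanin-concentrating hormone receptor 1 (Homo sapiens) as the target, read by fluorescence (on this read-out higher numbers stand for weaker inhibition and lower numbers for stronger inhibition), the lower of the two numbers so far; compound 1 `Nc1ccc2cccc(OCC3CCCC3)c2n1` gives 2290 nM. Compound 3 `Nc1ccc2cccc(OCC3CCOC3)c2n1` differs from compound 2 by (oxolan-3-yl)methyl in place of 1-methylbutyl on an oxygen on an aromatic ring. Going by the values given here, the one measured step, a 2.7-fold lower number from compound 1 to compound 2 (0.43 log units; beyond the scatter), ran the other way: cyclopentylmethyl replaced by 1-methylbutyl lowered the number by a modest amount. Compound 3 brings back a group carrying a five-membered ring, so a modest step upward is expected, of about a 2.7-fold higher number from compound 2 to compound 3 (0.43 log units; beyond the scatter). Compound 3 is therefore estimated at 2300 nM, with a likely range from 800 nM to 7000 nM.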

Compound 3, half-maximal inhibitory concentration: 6240 nM
Compound 3: the middle estimate sits 2.7-fold (0.43 log units) below what was measured, and the stated range covers the measured number.
By their numbers in this assay, from the lowest: compound 2; then compound 1; then compound 3.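

Exchanging cyclopentyl for oxolan-3-yl changes the ring by one oxygen, yet it gives a 2.7-fold higher number from compound 1 to compound 3 (0.44 log units; beyond the scatter), so this position responds to a change within the ring and not only to whether a ring is present. The step of a 7.3-fold higher number from compound 2 to compound 3 (0.86 log units; beyond the scatter) is the largest seen here, and a higher number means weaker inhibition. No available evidence explains the effect of this ring oxygen. Open questions are how an amine at the end of the chain would compare, and whether a longer unbranched carbon chain would lower the number below that of compound 2.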